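Adding an Amino Group to a Methoxy Nucleoside

A few compounds are considered here, and "the series" means these few. Any claim that something is new, unique, unknown or untested is made for them only; others in the source may bear on it.

Among the measured compounds shown here, compound 1 `COc1ncnc2c1c(-c1ccoc1)cn2[C@@H]1O[C@H](CO)[C@@H](O)[C@H]1O` was tested in a functional assay on HepG2 cells (Homo sapiens) for antiproliferative activity, read by XTT assay, with a stated time of 72 h (a lower number here means a stronger inhibitor, a higher number a weaker inhibitor), and gave 290 nM, the lowest of the two numbers so far. Compound 2 `CN(C)c1ncnc2c1c(-c1ccoc1)cn2[C@@H]1O[C@H](CO)[C@@H](O)[C@H]1O` gives 12500 nM in this assay; the step was a 43-fold higher number from compound 1 to compound 2 (1.63 log units; beyond the scatter). Compound 3 `COc1nc(N)nc2c1c(-c1ccoc1)cn2[C@@H]1O[C@H](CO)[C@@H](O)[C@H]1O` differs from compound 1 by amino in place of hydrogen on an aromatic carbon. For the measured compounds named here, no measured step concerns this place on the core; the only known step alters the methoxy group itself, so it offers little direct guidance. A modest weakening is expected, a 2.8-fold higher number from compound 1 to compound 3 (0.44 log units; beyond the scatter). Compound 3 is estimated at 800 nM, within 150 nM to 5000 nM.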

Compound 3, half-maximal inhibitory concentration: > 20000 nM
Compound 3 gave a limit, no number (the forecaster's own chance of this, stated with the estimate: 10%); middle value at least 25-fold (1.39 log units) away from the limit.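

The carbon between two ring nitrogen atoms, which carries only hydrogen in compound 1, proves highly sensitive to amino, with an at least 68-fold higher number from compound 1 to compound 3 (1.83 log units; beyond the scatter). Compound 3 stands at a limit of this assay rather than at a number: the limit of > 20000 nM in this assay, at which 1 of the 3 values shown sits. Compound 2 showed a response only at the methoxy place, whereas compound 3 shows that a second place on the core of compound 1 also responds strongly.

Going by these compounds, whether a methyl group or a chlorine atom on this carbon would keep the activity stays open. So does the effect of amino when dimethylamino replaces methoxy.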